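Sulfanyl link in place of propoxy on the outer ring

A few compounds are considered here, and "the series" means these few. Any claim that something is new, unique, unknown or untested is made for them only; others in the source may bear on it.

Two compounds of the shared core have been run in an ADME assay on microsomes from liver (Homo sapiens) for metabolic stability, read by LC-MS, tested at 0.5 uM; on this read-out lower numbers stand for a shorter-lived compound and higher numbers for a longer-lived compound. Compound 1 `COc1cccc(CCOc2ccc(-c3c(C)nc(C)c([C@H](OC(C)(C)C)C(=O)O)c3N3CCC(C)(C)CC3)cc2)c1` carries a 3-methoxyphenyl at the end of the chain. In this assay compound 1 gives > 2 h, which is a limit of the assay and not a number. Compound 2 `Cc1nc(C)c([C@H](OC(C)(C)C)C(=O)O)c(N2CCC(C)(C)CC2)c1-c1ccc(OCCCc2ccc(F)cc2)cc1` carries a 4-fluorobenzyl there. In this assay compound 2 gives > 2 h, again a limit rather than a number. The step that the two limits leave unreadable from compound 1 to compound 2 therefore cannot be sized. Among the compounds with values here, compound 2 stands at the limit of > 2 h in this assay, at which 2 of the 2 values shown sit, so nothing on the numbers so far separates it from compound 1.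

Compound 3 `Cc1nc(C)c([C@H](OC(C)(C)C)C(=O)O)c(N2CCC(C)(C)CC2)c1-c1ccc(SCCc2ccc(F)cc2)cc1` differs from compound 2 by (2-(4-fluorophenyl)ethyl)sulfanyl in place of 3-(4-fluorophenyl)propoxy on an aromatic carbon. Within the data shown here, no measured step bears on a change of the linking atom between the outer ring and the chain; the single step known, from compound 1 to compound 2, alters the far end of the chain and is unreadable. The expectation for compound 3 thus rests on compound 2 alone and is given a wide range. The expected step in this assay is a number no higher from compound 2 to compound 3 (the limit leaves the size open), with no direction beyond the scatter claimed. Compound 3 is estimated at 2 h, between 0.7 h and 4 h.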

Compound 3, half-life: > 2 h
Compound 3 was reported as a limit; the forecaster's own chance of this, stated with the estimate: 50%; the middle value lies on the limit itself.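

In this assay compound 3 gives > 2 h, a limit of the assay and not a number. Within the data shown here, no step among compound 1, compound 2 and compound 3 can be read: the limit of > 2 h in this assay, at which 3 of the 3 values shown sit. The compounds shown leave open how long each one actually lasts and whether the sulfanyl link changes that relative to the propoxy link.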